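A Triazole Aryl Swap at the Assay Ceiling

This account rests on a few compounds, and the source may have more. Where it says the series, first, only, none or still open, it means among the compounds named here.

Compound 3 `CC(=O)Nc1ccc(-n2nncc2CN2C(=O)C3(C(C#N)=C(N)Oc4c3c3nc5ccccc5nc3c3ccccc43)c3ccccc32)cc1` is one of three close relatives tested in a functional assay on HCT-116 cells (Homo sapiens) for antiproliferative activity, read by MTT assay, with a stated time of 48 h; a higher number here means a weaker inhibitor, a lower number a stronger inhibitor. In this assay compound 3 gives > 50000 nM, which is a limit of the assay rather than a number. Compound 1 `N#CC1=C(N)Oc2c(c3nc4ccccc4nc3c3ccccc23)C12C(=O)N(Cc1cnnn1-c1ccc(Cl)cc1)c1ccccc12` gives > 50000 nM in this assay, again a limit. Compound 2 `N#CC1=C(N)Oc2c(c3nc4ccccc4nc3c3ccccc23)C12C(=O)N(Cc1cnnn1-c1cccc(Br)c1)c1ccccc12` gives > 50000 nM in this assay, also a limit. Compound 3 therefore stands where every measured compound stands, namely at the limit of > 50000 nM in this assay, at which 3 of the 3 values shown sit. The steps a step that the two limits leave unreadable from compound 1 to compound 2, a step that the two limits leave unreadable from compound 1 to compound 3 and a step that the two limits leave unreadable from compound 2 to compound 3 are all of unreadable size.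

Compound 4 `Cc1ccc(Cl)cc1-n1nncc1CN1C(=O)C2(C(C#N)=C(N)Oc3c2c2nc4ccccc4nc2c2ccccc32)c2ccccc21` differs from compound 3 in one place: 5-chloro-2-methylphenyl in place of 4-acetamidophenyl on an aromatic nitrogen. The measured steps bear on this change only in that each exchange of the group on the aromatic nitrogen of the five-membered ring with three nitrogens left the compound at the limit. Among the measured compounds shown here, no step shows a readable size or direction, so the expectation is that compound 4 will again sit at the limit. Compound 4 is expected to give 80000 nM, within 30000 nM to 300000 nM, which would mean a step that the limit leaves unreadable from compound 3 to compound 4 that the limits leave unreadable.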

Compound 4, half-maximal inhibitory concentration: > 50000 nM
Compound 4: a limit, no number (the forecaster's own chance of this, stated with the estimate: 85%); the middle value is on the limit's open side.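

Compound 4 gives no number in this assay, and its steps from compound 1, compound 2 and compound 3 cannot be read, since all four stand at one limit: the limit of > 50000 nM in this assay, at which 4 of the 4 values shown sit. Still open, as far as these compounds go, is whether any group on that aromatic nitrogen gives a measurable value in this assay.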